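A Hydroxyl for a Chlorine at the Far Ring

This account rests on a few compounds, and the source may have more. Where it says the series, first, only, none or still open, it means among the compounds named here.

Two compounds share a core and differ in one place. Compound 1 `Cc1ccc2[nH]c(-c3ccc(-c4ccc(-c5cccc(Cl)c5)cc4)cc3)nc2c1` is the stronger of the pair in a functional assay on ZR-75-1 cells (Homo sapiens) for inhibition, read by sulforhodamine B assay; a lower number here means a stronger inhibitor of growth, a higher number a weaker inhibitor of growth: compound 1 gives 3450 nM, while compound 2 `Clc1cccc(-c2ccc(-c3ccc(-c4nc5ccccc5[nH]4)cc3)cc2)c1` gives 41200 nM. Going by the values given here, the only measured step, a 12-fold higher number from compound 1 to compound 2 (1.08 log units; beyond the scatter), concerns a group on the shared core, not the outer ring.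

Compound 3 `Cc1ccc2[nH]c(-c3ccc(-c4ccc(-c5ccc(O)cc5)cc4)cc3)nc2c1` changes a different part of compound 1: 4-hydroxyphenyl in place of 3-chlorophenyl on an aromatic carbon. Among the compounds with values here, no measured step touches this outer ring, so nothing seen so far tells how the assay responds to such a change; the step from compound 1 to compound 2 bears on another position and gives no guide here. The expectation is therefore a step near zero, with wide uncertainty: a 1.2-fold higher number from compound 1 to compound 3 (0.06 log units; within the scatter). Compound 3 is estimated at 4000 nM, within 1000 nM to 16000 nM.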

Compound 3, concentration for 50% growth inhibition: 18200 nM
Estimate against measurement, compound 3: 4.6-fold (0.66 log units) below; measured number outside the range, above it.
By their numbers in this assay, from the lowest: compound 1; then compound 3; then compound 2.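

The far ring matters in this assay: 4-hydroxyphenyl in place of 3-chlorophenyl gives a 5.3-fold higher number from compound 1 to compound 3 (0.72 log units; beyond the scatter) and so weakens growth inhibition by more than the usual scatter. This single step changes both the group and its ring position, replacing chlorine with hydroxyl and adding a hydrogen-bond donor and acceptor, so it cannot show which of these differences counts. Nothing measured here explains the weaker result.

Still open, as far as these compounds go, is whether the hydroxyl itself or its ring position accounts for the step, a question that 3-hydroxyphenyl and 4-chlorophenyl rings on the same core could help settle. Also open, from the compounds shown here alone, is how this outer ring would respond to other groups, such as an amine or a carboxylic acid.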